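Swapping Trifluoromethyl for Chloro on an Aryl Alkyne Acid

This account rests on a few compounds, and the source may have more. Where it says the series, first, only, none or still open, it means among the compounds named here.

Measured so far:
- compound 1, `Cn1ccnc1C#Cc1cc(Cl)ccc1OCC(=O)O`: 1470 nM
- compound 2, `O=C(O)COc1ccc(Cl)cc1C#Cc1ccccc1C(F)(F)F`: 24 nM

In an assay on CHO cells for displacement of a labelled ligand from prostaglandin D2 receptor 2 (Homo sapiens), read by scintillation counting (a higher number here means a weaker inhibitor, a lower number a stronger inhibitor), compound 1 gives 1470 nM, while compound 2 gives 24 nM. Of the two numbers, compound 2 has the lowest; the gap to compound 1 is well beyond the usual scatter, so compound 2 is the stronger binder of the pair.

Compound 3, `O=C(O)COc1ccc(Cl)cc1C#Cc1ccccc1Cl`, is not yet measured. It differs from compound 2 in one place: chloro in place of trifluoromethyl on an aromatic carbon. Both groups are small and uncharged, and the rest of the molecule is untouched. For the measured compounds named here, no measured pair shows this particular exchange, so there is no direct precedent to lean on. The step expected from compound 2 to compound 3 in this assay is a 1.7-fold higher number from compound 2 to compound 3 (0.22 log units; within the scatter), that is, a change no larger than the scatter, with perhaps a mild drift toward a higher number. Compound 3 is therefore estimated at 40 nM, with a plausible range from 12 nM to 130 nM.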

Compound 3, inhibition constant: 28 nM
Compound 3: the middle estimate sits 1.4-fold (0.15 log units) above what was measured, within the range that was stated.
By their numbers in this assay, from the lowest: compounds 2 and 3 (each within the scatter of the next); then compound 1.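

In this assay, chloro in place of trifluoromethyl on this aromatic carbon gives a 1.2-fold higher number from compound 2 to compound 3 (0.07 log units; within the scatter), so a single chlorine atom serves as well here as the four heavy atoms it replaces, at least by this read-out. Placing 2-chlorophenyl in place of 1-methyl-1H-imidazol-2-yl on the triple-bonded carbon gives a 53-fold lower number from compound 1 to compound 3 (1.72 log units; beyond the scatter), so the large gap first seen with compound 2 does not depend on trifluoromethyl, and compound 3 reaches it with chloro instead. Nothing at hand explains either step.

Going by these compounds, whether a methoxy group, an amine or a nitrile on the same aromatic carbon would also stay within the scatter of these two remains open. Also open, on these data alone, is whether this exchange would give an equally small step in a compound carrying a tetrazole in place of the carboxylic acid.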